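Cyclopropylamino to diethylamino on the carbonyl carbon

The source may report more compounds than this note shows. Statements on the series, on what has been measured and on what is new or still open speak of the compounds shown alone.

In a functional assay on K562 cells (Homo sapiens) for inhibition, read by MTT assay, with a stated time of 48 h (a higher number here means a weaker inhibitor, a lower number a stronger inhibitor), compound 1 `Nc1ccc(-c2cn([C@@H]3CN[C@H](C(=O)Nc4ccc(Cl)c(C(F)(F)F)c4)C3)nn2)cn1` gives 10400 nM and compound 2 `O=C(NC1CC1)c1cncc(-c2cn([C@@H]3CN[C@H](C(=O)Nc4ccc(Cl)c(C(F)(F)F)c4)C3)nn2)c1` gives 820 nM, the lower of the two numbers. Compound 3 `CCN(CC)C(=O)c1cncc(-c2cn([C@@H]3CN[C@H](C(=O)Nc4ccc(Cl)c(C(F)(F)F)c4)C3)nn2)c1` keeps the rest of compound 2 and differs in one group: diethylamino in place of cyclopropylamino on a carbonyl carbon. For the measured compounds named here, the only measured step is large, a 13-fold lower number from compound 1 to compound 2 (1.10 log units; beyond the scatter), but it exchanged the whole 6-aminopyridin-3-yl group, so it gives only loose guidance here. Going by the values given here, no measured compound carries diethylamino. A small rise in the number is expected in this assay. The expected change is a 1.7-fold higher number from compound 2 to compound 3 (0.23 log units; within the scatter). For compound 3 the estimate is 1400 nM, with an expected range of 450 nM to 4500 nM.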

Compound 3, half-maximal inhibitory concentration: 27600 nM
Compound 3: middle estimate off by 20-fold (1.29 log units), on the low side, outside the stated range (above it).
By their numbers in this assay, from the lowest: compound 2; then compound 1; then compound 3.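

Diethylamino in place of cyclopropylamino on the carbonyl carbon gives a 34-fold higher number from compound 2 to compound 3 (1.53 log units; beyond the scatter) in this assay and so shows that this amide substituent, not only the group exchanged in the earlier step, strongly affects the number. The change removes the three-membered ring and the one hydrogen-bond donor together, so these two differences cannot be separated here. Nothing available explains the size of this step.

An ethylamino group would keep the donor without the ring, while a pyrrolidin-1-yl group would keep a ring without the donor. As far as these compounds go, how either compares with cyclopropylamino remains open.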